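Moving a Hydroxyl Group on a Shared Pyridine-Free Core

This account rests on a few compounds, and the source may have more. Where it says the series, first, only, none or still open, it means among the compounds named here.

Two compounds share one core and were tested in a functional assay on T47D cells (Homo sapiens) for inhibition; a higher number here means a weaker inhibitor, a lower number a stronger inhibitor. Compound 1 `Oc1ccc(-c2cc(-c3ccccc3C(F)(F)F)cc(-c3ccccc3O)n2)cc1` gives 7180 nM. Compound 2 `Oc1ccccc1-c1cc(-c2ccccc2OC(F)(F)F)cc(-c2ccccc2O)n1` gives 1730 nM, the lower of the two numbers, and the gap to compound 1 lies beyond the usual scatter. Compound 3 `Oc1ccc(-c2cc(-c3ccccc3OC(F)(F)F)cc(-c3ccccc3O)n2)cc1` has not been measured. It differs from compound 2 in one place: 4-hydroxyphenyl in place of 2-hydroxyphenyl on an aromatic carbon. Going by the values given here, no measured pair shows this change alone, so its size is uncertain. A modest weakening is expected, with the step from compound 2 to compound 3 estimated at a 2.0-fold higher number from compound 2 to compound 3 (0.31 log units; beyond the scatter). Compound 3 is expected to give 3500 nM, within 1200 nM to 10000 nM.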

Compound 3, half-maximal inhibitory concentration: 2050 nM
Estimate against measurement, compound 3: 1.7-fold (0.23 log units) above; low and high end bracket the measured number.
By their numbers in this assay, from the lowest: compounds 2 and 3 (each within the scatter of the next); then compound 1.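

In this assay, moving the hydroxyl so that 4-hydroxyphenyl replaces 2-hydroxyphenyl at this position makes no clear difference, with a 1.2-fold higher number from compound 2 to compound 3 (0.07 log units; within the scatter). Trifluoromethoxy in place of trifluoromethyl does make a clear difference, with a 3.5-fold lower number from compound 1 to compound 3 (0.54 log units; beyond the scatter). Nothing measured here explains either step. Still open, as far as these compounds go, is how this position would respond to a phenyl ring carrying an amine or a carboxylic acid instead of the hydroxyl, since only two hydroxyl placements appear here.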